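Sulfonamide benzoxazole series: fluoro for methoxy step

The source may hold more compounds than are shown below. What is called first, only, known or untested is meant among the compounds shown, and "the series" means these compounds.

Measured compounds in an assay on isolated protein for inhibition of malate dehydrogenase, mitochondrial (Sus scrofa), with stated times of 45 min and 30 min; a lower number here means a stronger inhibitor, a higher number a weaker inhibitor:
- compound 1 `Cc1cccc(S(=O)(=O)Nc2ccc(-c3nc4ccccc4o3)cc2)c1`; in this assay compound 1 gives > 63000 nM, which is a limit of the assay and not a number.
- compound 2 `O=S(=O)(Nc1ccc(-c2nc3ccccc3o2)cc1)c1ccc(Cl)s1`; in this assay compound 2 gives > 63000 nM, again a limit.
- compound 3 `COc1cccc(S(=O)(=O)Nc2ccc(-c3nc4ccccc4o3)cc2)c1`; in this assay compound 3 gives > 63000 nM, likewise a limit.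

Compound 3 therefore stands at the limit of this assay, as do the two other measured compounds (the limit of > 63000 nM in this assay, at which 3 of the 3 values shown sit). None of the three measured steps can be read: a step that the two limits leave unreadable from compound 1 to compound 2, a step that the two limits leave unreadable from compound 1 to compound 3 and a step that the two limits leave unreadable from compound 2 to compound 3 are all hidden by the limits on both sides, so no size or direction of any step is known in this series.

Compound 4 `O=S(=O)(Nc1ccc(-c2nc3ccccc3o2)cc1)c1cccc(F)c1` is not yet measured in this assay. It differs from compound 3 as follows: fluoro in place of methoxy on an aromatic carbon. For the measured compounds named here, the only step that bears on it, from compound 1 to compound 3, is unreadable, so there is no measured basis for expecting a readable step in either direction. The step from compound 3 to compound 4 is therefore expected to be a step that the limit leaves unreadable from compound 3 to compound 4, meaning an estimated value at or beyond the limit. Compound 4 is estimated at 100000 nM, with an expected range from 40000 nM to 300000 nM, most likely reported as a limit only.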

Compound 4, half-maximal inhibitory concentration: > 63000 nM
Compound 4 ended at the assay's limit (the forecaster's own chance of this, stated with the estimate: 85%); the middle value lies beyond the limit too.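

In this assay compound 4 gives > 63000 nM, which is a limit and not a number. Its steps from compound 1, compound 2 and compound 3 cannot be read, since all four compounds sit at the same limit: the limit of > 63000 nM in this assay, at which 4 of the 4 values shown sit.

The compounds shown leave open the size and direction of every step in this series, and which change, if any, would give a readable value.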